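The source may report more compounds than this note shows. Statements on the series, on what has been measured and on what is new or still open speak of the compounds shown alone.

Of the compounds shown here, two from this series have so far been tested in a functional assay on CHO cells for positive allosteric modulation of metabotropic glutamate receptor 2 (Homo sapiens), with a stated time of 30 min; a higher number here means a larger maximal response, a lower number a smaller maximal response. Compound 1 `CCCCn1ccc(N2CCC(c3ccccc3)CC2)c(C#N)c1=O` gives 309%. Compound 2 `N#Cc1c(N2CCC(c3ccccc3F)CC2)ccn(CC2CC2)c1=O` gives 282%, the lower of the two numbers, with compound 1 standing higher by a margin that exceeds the usual scatter of the measurement. The next compound, compound 3 `COc1ccccc1C1CCN(c2ccn(CC3CC3)c(=O)c2C#N)CC1`, has not yet been tested. It differs from compound 2 in one place: methoxy in place of fluoro on an aromatic carbon. For the measured compounds named here, no pair of measured compounds shows this particular change, so there is no directly comparable step to lean on; the only guide is that the two measured values lie reasonably close together. For compound 3 the estimated maximal response is 280%, within a range from 220% to 340%. The expected step of a number 2 percentage points lower from compound 2 to compound 3 (within the scatter) is therefore small and may well fall within the scatter rather than beyond it.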

Compound 3, largest response reached (Emax), in percent of the reference or control that the assay uses: 265%
The estimate for compound 3 lay 15 percentage points above the measured number; low and high end bracket the measured number.
By their numbers in this assay, from the lowest: compound 3; then compound 2; then compound 1.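

In this assay, putting methoxy in place of fluoro on the aromatic carbon ortho to a large group leaves the maximal response a number 17 percentage points lower from compound 2 to compound 3 (beyond the scatter) and gives the series its first comparison that changes one place only. The step is modest, and compound 3 still reaches 265% with 2-methoxyphenyl in place of 2-fluorophenyl, so this position tolerates the exchange with only a limited loss of maximal response. No measurement available here explains the step.

As far as these compounds go, it remains open how a plain hydrogen, an amine or an ethoxy group on the same aromatic carbon would compare with compound 2 and compound 3. From the compounds shown here alone, it is also open whether the same exchange would give a similar step on a compound carrying the butyl chain of compound 1.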